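Swapping the Group on the Aromatic Nitrogen

This account rests on a few compounds, and the source may have more. Where it says the series, first, only, none or still open, it means among the compounds named here.

In a functional assay on RAW264.7 cells (Mus musculus) for inhibition, read by Griess assay, with stated times of 2 h and 24 h (on this read-out higher numbers stand for weaker inhibition and lower numbers for stronger inhibition), three compounds have been measured so far:
compound 1 `CCn1cc(COc2cc(O)c3c(c2)O[C@H](c2ccc(OC)c(O)c2)C/C3=N\O)nn1` gives 3140 nM;
compound 2 `CCCn1cc(COc2cc(O)c3c(c2)O[C@H](c2ccc(OC)c(O)c2)C/C3=N\O)nn1` gives 2340 nM;
compound 3 `COc1ccc([C@@H]2CC(=O)c3c(O)cc(OCc4cn(Cc5ccccc5Cl)nn4)cc3O2)cc1O` gives 6140 nM.

Compound 3 carries the highest number of the three; its gap to compound 1 lies within the scatter, while its gap to compound 2 lies beyond it. Compound 4 `COc1ccc([C@@H]2CC(=O)c3c(O)cc(OCc4cn(C5CCC5)nn4)cc3O2)cc1O` differs from compound 3 by cyclobutyl in place of 2-chlorobenzyl on an aromatic nitrogen. Among the compounds with values here, the only measured step, a 1.3-fold lower number from compound 1 to compound 2 (0.13 log units; within the scatter), concerns a different change on the same nitrogen and sits on a core that differs from that of compound 3, so it offers little guidance; compounds 1 and 2 also differ from compound 3 in two places, and no step between them is available. Little movement in this assay is therefore expected. Compound 4 is estimated at 4500 nM, between 1800 nM and 11000 nM. The expected step is a 1.4-fold lower number from compound 3 to compound 4 (0.13 log units; within the scatter).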

Compound 4, half-maximal inhibitory concentration: 15300 nM
Estimate against measurement, compound 4: 3.4-fold (0.53 log units) below; the measured number lies above the stated range.
By their numbers in this assay, from the lowest: compounds 2, 1 and 3 (each within the scatter of the next, the first and the last beyond it); then compound 4.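

In this assay, the group on this aromatic nitrogen matters on the core of compound 3: cyclobutyl in place of 2-chlorobenzyl gives a 2.5-fold higher number from compound 3 to compound 4 (0.40 log units; beyond the scatter) and so weakens inhibition. Within the data shown here, the only earlier step at this nitrogen stayed within the scatter, so this is the first change there that clearly moves the number. Nothing at hand accounts for the loss. Open, going by these compounds, is whether it follows the loss of the chlorine or of the six-membered aromatic ring, which plain benzyl could separate. Also open, on these data alone, is whether the same swap would act alike on the core of compound 1.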